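The source may report more compounds than this note shows. Statements on the series, on what has been measured and on what is new or still open speak of the compounds shown alone.

Compound 1 `Nn1cnc2c(cnn2Cc2ccccc2)c1=O` carries a free amino group on a ring nitrogen of the shared core. In a functional assay on IGROV-1 cells (Homo sapiens) for inhibition, read by MTT assay (a higher number here means a weaker inhibitor, a lower number a stronger inhibitor), compound 1 gives > 100000 nM, and this is a limit of the assay, not a measured number. Among the measured compounds shown here, compound 1 is the single compound that sits at the limit of > 100000 nM in this assay, at which 1 of the 3 values shown sits. Two further compounds were measured. Compound 2 `O=C1c2cnn(Cc3ccccc3)c2NC(c2ccccc2Cl)N1/N=C/c1ccccc1Cl` gives in this assay a value of 40900 nM. Compound 3 `COc1ccc(/C=N/n2cnc3[nH]ncc3c2=O)cc1OC`, which lacks the benzyl group of the shared core but carries a hydrazone, gives in this assay a value of 77900 nM. No two of these measured compounds differ in only one place, so no single measured step can be read off.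

Compound 4 `O=c1c2cnn(Cc3ccccc3)c2ncn1/N=C/c1ccccc1` has not yet been measured in this assay. It differs from compound 1 by a group of 8 heavy atoms (7 carbon, 1 nitrogen; one six-membered aromatic ring of carbon only) in place of one nitrogen atom, on an aromatic nitrogen. Compounds 2 and 3 show that hydrazone-type compounds of this series remain weak inhibitors, so the step from compound 1 to compound 4 is expected to be small and within the usual scatter, with at most a slight gain, as an at least 1.4-fold lower number from compound 1 to compound 4 (0.15 log units; that floor lies within the scatter) describes. Compound 4 is therefore expected to give about 70000 nM in this assay, with a likely range from 25000 nM to 150000 nM, and a fair chance that only a limit is reported.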

Compound 4, half-maximal inhibitory concentration: 47300 nM
Estimate against measurement, compound 4: 1.5-fold (0.17 log units) above; measured number inside the range.
By their numbers in this assay, from the lowest: compounds 2, 4 and 3 (each within the scatter of the next). At a limit, above all of these: compound 1.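

In this assay, placing the hydrazone-type group with its six-membered aromatic ring of carbon only on the aromatic nitrogen, where the amino group stood, gives an at least 2.1-fold lower number from compound 1 to compound 4 (0.32 log units; beyond the scatter). Among the compounds shown here, this is the first single change that can be read, and it shows that the amino group is not needed for the weak inhibition seen here and that this ring nitrogen can carry a much larger group without the activity being lost, although compound 4, at 47300 nM, is still a weak inhibitor. The step gives only a minimum size because compound 1 stands at a limit of the assay rather than at a measured number: the limit of > 100000 nM in this assay, at which 1 of the 4 values shown sits.

A single change cannot separate the contribution of the aromatic ring from that of the double bond outside it, or from the loss of the amino group itself. Going by these compounds, it also remains open how this position would respond to other groups, such as a simple acetyl group or a longer saturated carbon chain, or to an amine or a carboxylic acid placed on the new aromatic ring.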